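One Aryl Swap on a Shared Core

This account rests on a few compounds, and the source may have more. Where it says the series, first, only, none or still open, it means among the compounds named here.

Compound 1 `O=C1C=C(Nc2ccc(I)cc2)C(=O)c2c1nc1n2[C@H]2OC[C@@H](O)[C@H]2OC1` gives 1400 nM in a functional assay on MGC-803 cells (Homo sapiens) for inhibition, read by sulforhodamine B assay; on this read-out lower numbers stand for stronger inhibition and higher numbers for weaker inhibition. Compound 2 `O=C1C=C(Nc2cccc(Cl)c2)C(=O)c2c1nc1n2[C@H]2OC[C@@H](O)[C@H]2OC1` gives 1770 nM in this assay and stands at the top of the two numbers shown, separated from compound 1 only by a 1.3-fold higher number from compound 1 to compound 2 (0.10 log units; within the scatter). Compound 3 `CCOc1ccc(NC2=CC(=O)c3nc4n(c3C2=O)[C@H]2OC[C@@H](O)[C@H]2OC4)cc1` differs from compound 2 by 4-ethoxyphenyl in place of 3-chlorophenyl on an amine nitrogen. Within the data shown here, only that one measured step bears on the change, and it was small, so the expected step in this assay is a 1.0-fold higher number from compound 2 to compound 3 (0.01 log units; within the scatter), nothing beyond the scatter. Compound 3 is therefore estimated to give about 1800 nM, between 700 nM and 4500 nM.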

Compound 3, half-maximal inhibitory concentration: 1110 nM
Compound 3: the middle estimate sits 1.6-fold (0.21 log units) above what was measured; the range from low to high includes it.
By their numbers in this assay, from the lowest: compounds 3, 1 and 2 (each within the scatter of the next).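

With 4-ethoxyphenyl, the only one of the three aryl groups carrying a hydrogen-bond acceptor, the amine nitrogen gives a 1.6-fold lower number from compound 2 to compound 3 (0.20 log units; within the scatter) in this assay and no step beyond the scatter. Ethoxy in place of iodo on an aromatic carbon likewise gives a 1.3-fold lower number from compound 1 to compound 3 (0.10 log units; within the scatter) and leaves all three compounds within the scatter of one another, so these three aryl groups do not separate on the shared core. No evidence at hand explains these numbers.

From the compounds shown here alone, whether an amine or a carboxylic acid on the phenyl ring, or a longer chain in place of ethoxy, would give a step beyond the scatter remains open.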